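Removing the cyclopropyl ring from compound 2

This account rests on a few compounds, and the source may have more. Where it says the series, first, only, none or still open, it means among the compounds named here.

In a functional assay on MCF7 cells (Homo sapiens) for cytotoxicity, read by MTT assay, with a stated time of 24 h (on this read-out lower numbers stand for stronger inhibition and higher numbers for weaker inhibition), compound 2 `O=C(Nc1cccc(Cl)c1)Nc1ccc(-c2ccnc(NCC3CC3)c2)c(C(F)(F)F)c1` gives 17400 nM. Compound 3 `O=C(Nc1ccc(C(F)(F)F)cc1)Nc1ccc(-c2ccnc(NCC3CC3)c2)c(C(F)(F)F)c1` gives 15600 nM, and the two share the high end of the measured numbers, while compound 1 `CCNc1cc(-c2ccc(NC(=O)Nc3cccc(Cl)c3)cc2C(F)(F)F)ccn1` gives a much lower 1240 nM. Compound 4 `CCCNc1cc(-c2ccc(NC(=O)Nc3cccc(Cl)c3)cc2C(F)(F)F)ccn1` differs from compound 2 by one change: ethyl in place of cyclopropyl on a saturated chain carbon bound to a nitrogen on an aromatic ring. The ring of compound 2 is thus lost and an open chain takes its place. The best guide is a 14-fold higher number from compound 1 to compound 2 (1.15 log units; beyond the scatter), a large step at that same place, where cyclopropyl stands in place of methyl. The other measured step, a 1.1-fold lower number from compound 2 to compound 3 (0.05 log units; within the scatter), lies elsewhere and says little. Losing the ring should therefore undo part of that large step, so a lower number is expected in this assay. The expected change is a 3.5-fold lower number from compound 2 to compound 4 (0.54 log units; beyond the scatter). For compound 4 the estimate is 5000 nM, with an expected range of 1500 nM to 16000 nM.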

Compound 4, half-maximal inhibitory concentration: 8230 nM
Estimate against measurement, compound 4: 1.6-fold (0.22 log units) below, and the stated range covers the measured number.
By their numbers in this assay, from the lowest: compound 1; then compounds 4, 3 and 2 (each within the scatter of the next, the first and the last beyond it).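

In this assay, replacing the cyclopropyl ring with the open ethyl recovers only part of the earlier large rise (a 2.1-fold lower number from compound 2 to compound 4 (0.33 log units; beyond the scatter)). The added chain carbon alone already gives a clear rise (a 6.6-fold higher number from compound 1 to compound 4 (0.82 log units; beyond the scatter)). At this position, then, most of the rise from compound 1 to compound 2 is already present in the open propyl chain of compound 4, and closing the ring adds a smaller part.

On these data alone, whether a longer chain such as butyl raises the number further, or a bare amine lowers it, stays open. No evidence is available to explain these differences.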